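Dithiolethione in place of thioamide on a capped diester

The compounds below may be only part of what the source reports. "The series", "measured", "known", "first", "only" and "open" are said of these compounds alone.

Compound 1 `COc1cc(CNC(=O)CCCCCCC(C)C)ccc1OC(=O)CCC(=O)Oc1ccc(C(N)=S)cc1` was tested in a functional assay on HeLa cells (Homo sapiens) for antiproliferative activity, read by MTT assay, with a stated time of 48 h; a higher number here means a weaker inhibitor, a lower number a stronger inhibitor. In this assay compound 1 gives > 50000 nM, which is a limit of the assay and not a number. Compound 2 `COc1cc(CNC(=O)CCCC/C=C/C(C)C)ccc1OC(=O)CCC(=O)Oc1ccc(C(N)=S)cc1` likewise gives > 50000 nM, also a limit. Compound 3 `COc1cc(CNC(=O)CCCC/C=C/C(C)C)ccc1OCCCCCOc1ccc(C(N)=S)cc1` gives 46400 nM. Within the data shown here, the only single-change comparison among them, a step that the two limits leave unreadable from compound 1 to compound 2, is thus unreadable, and the limit of > 50000 nM in this assay, at which 2 of the 3 values shown sit, describes where compound 1 stands. Compound 4 `COc1cc(CNC(=O)CCCCCCC(C)C)ccc1OC(=O)CCC(=O)Oc1ccc(-c2cc(=S)ss2)cc1` differs from compound 1 by a group of 6 heavy atoms (3 carbon, 3 sulfur; one five-membered aromatic ring with 2 hetero atoms) in place of a group of 3 heavy atoms (1 carbon, 1 nitrogen, 1 sulfur; no ring), on an aromatic carbon. Among the measured compounds shown here, no measured step touches this group, so neither direction nor size can be read from the data. Compound 4 is therefore expected to stay near the limit, an estimated step of an at least 1.4-fold lower number from compound 1 to compound 4 (0.15 log units; that floor lies within the scatter). For compound 4 the estimated value is 35000 nM, expected between 10000 nM and 100000 nM.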

Compound 4, half-maximal inhibitory concentration: 5530 nM
For compound 4 the middle estimate is 6.3-fold (0.80 log units) above the measured one; measured number below the stated range.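

In this assay, among these compounds, the first readable step at this aromatic carbon, para to a large group, is an at least 9.0-fold lower number from compound 1 to compound 4 (0.95 log units; beyond the scatter). This shows that the position tolerates the larger group with its five-membered aromatic ring, and that the change moves the result off the limit, which the change in the chain of compound 2 could not be shown to do. Compound 1 itself stays at a limit of the assay, so the true size of the step remains unknown: the limit of > 50000 nM in this assay, at which 2 of the 4 values shown sit.

The compounds shown leave open whether this ring has the same effect on the core of compound 3. They also leave open how a carboxylic acid or a nitrile at this carbon would compare.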